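The source may report more compounds than this note shows. Statements on the series, on what has been measured and on what is new or still open speak of the compounds shown alone.

Compound 1 `NS(=O)(=O)c1ccc(C(=O)N/N=C\c2ccccc2)cc1` and compound 2 `NS(=O)(=O)c1ccc(C(=O)N/N=C\c2ccc(Br)cc2)cc1` share one core, while compound 3 `NS(=O)(=O)c1ccc(N/N=C(/CS(=O)(=O)c2ccccc2)c2ccccc2)cc1` and compound 4 `NS(=O)(=O)c1ccc(N/N=C(/CS(=O)(=O)c2ccccc2)c2ccc(Br)cc2)cc1` share another; the difference between the two cores is not broken down here. In an ADME assay on MCF-10A cells (Homo sapiens) for antiproliferative activity, read by MTT assay (a lower number here means a stronger inhibitor, a higher number a weaker inhibitor), compound 1 gives 39400 nM. Compound 2 gives 27700 nM in this assay, a change described as a 1.4-fold lower number from compound 1 to compound 2 (0.15 log units; within the scatter), brought about by bromo in place of hydrogen on an aromatic carbon. Compound 3 gives 46100 nM in this assay; its number sits within the scatter of both compound 1 and compound 2, so no order among the three can be read from these data.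

Compound 4 is not yet measured. It differs from compound 3 by bromo in place of hydrogen on an aromatic carbon, the same change as that from compound 1 to compound 2, and the place on the ring is described in identical words for both pairs. For the measured compounds named here, the only guide for compound 4 is therefore the single measured instance of this change, on a different core, which stayed within the scatter.

On that basis compound 4 is expected to give 33000 nM in this assay, with a likely range from 15000 nM to 70000 nM. Going by the values given here, the step that this estimate implies, a 1.4-fold lower number from compound 3 to compound 4 (0.15 log units; within the scatter), is expected to be of the same modest size as the measured step because a 1.4-fold lower number from compound 1 to compound 2 (0.15 log units; within the scatter) is the only precedent, and a number anywhere within the scatter of compound 3 would be unsurprising.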

Compound 4, half-maximal inhibitory concentration: 12900 nM
The estimate for compound 4 lay 2.6-fold (0.41 log units) above the measured number; the whole stated range lies above it.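

In this assay, the change from phenyl to 4-bromophenyl on the core of compound 3 gives a 3.6-fold lower number from compound 3 to compound 4 (0.55 log units; beyond the scatter), a step that lies beyond the scatter, whereas the earlier step on the core of compound 1 stayed within it. Set side by side, however, the two steps cannot be told apart: the same change on two cores in this assay, a 1.4-fold lower number (0.15 log units; within the scatter) from compound 1 to compound 2 and a 3.6-fold lower number (0.55 log units; beyond the scatter) from compound 3 to compound 4, 2.5-fold (0.40 log units) apart, within the scatter of two such steps. For the compounds shown here, this shows that the larger step on the core of compound 3 is compatible with the smaller one on the core of compound 1, but it does not show that the core alters what the bromo does, nor that the change carries over unchanged in size, since only two pairs bear on the question.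

The compounds shown leave open whether another group in the same place, such as chloro, methoxy, an amine or a carboxylic acid, would follow bromo on either core. On these data alone, it also remains open how either core would respond to bromo at another place on the ring, or to a longer chain in place of the phenyl on the sulfonyl group of compound 3 and compound 4.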